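Removing the nitrile from compound 2: an expected outcome

A few compounds are considered here, and "the series" means these few. Any claim that something is new, unique, unknown or untested is made for them only; others in the source may bear on it.

Of the compounds shown here, three of one series have been measured in a toxicity assay on HUVEC cells (Homo sapiens) for inhibition; a higher number here means a weaker inhibitor of growth, a lower number a stronger inhibitor of growth. Going by the values given here, compound 1 `Cc1nc(-c2ccccc2F)c(C(=O)N2CCN(c3cc(Cl)cc(Cl)c3)CC2)o1` gives 0.177 ug/mL, and compound 3 `Cc1nc(-c2cccc(F)c2)c(C(=O)N2CCN(c3cc(Cl)cc(Cl)c3)CC2)o1` gives 0.134 ug/mL; the only single-place step between measured compounds, a 1.3-fold lower number from compound 1 to compound 3 (0.12 log units; within the scatter), moves the fluorine on the aryl attached to the shared core and stays within the scatter. Compound 2 `Cc1nc(-c2ccccc2)c(C(=O)N2CCN(c3cccc(C#N)c3)CC2)o1` gives 2.52 ug/mL, the highest of the three numbers and beyond the scatter from both compound 1 and compound 3, though compound 2 differs from them in more than one place, so those gaps are not single steps.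

Compound 4 `Cc1nc(-c2ccccc2)c(C(=O)N2CCN(c3ccccc3)CC2)o1` differs from compound 2 by hydrogen in place of cyano on an aromatic carbon, that is, 3-cyanophenyl becomes phenyl. Among the compounds with values here, no measured step touches this aryl, and the step from compound 1 to compound 3 concerns a different part of the molecule, so it offers no direct guide. With no bearing evidence, the expectation in this assay is a step of a 1.2-fold higher number from compound 2 to compound 4 (0.08 log units; within the scatter), likely within the scatter. Compound 4 is therefore estimated at 3 ug/mL, in the range 1 ug/mL to 10 ug/mL.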

Compound 4, concentration for 50% growth inhibition: 9.63 ug/mL
Estimate against measurement, compound 4: 3.2-fold (0.51 log units) below, within the range that was stated.
By their numbers in this assay, from the lowest: compounds 3 and 1 (each within the scatter of the next); then compound 2; then compound 4.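

The first step measured on this aryl shows that the cyano group at this place is not a neutral substituent in this assay: hydrogen in place of cyano, the change from 3-cyanophenyl to phenyl, gives a 3.8-fold higher number from compound 2 to compound 4 (0.58 log units; beyond the scatter). Going by these compounds alone, the earlier single-place step, the fluorine move on the other aryl, stayed within the scatter, so this is the first single change to shift the number beyond it, and the shift is towards weaker inhibition of growth. Nothing among the data shown accounts for this shift.

The compounds shown leave open whether a methoxy group, an amine or a carboxylic acid at this same place would keep the lower number seen with cyano or fall with hydrogen. They also leave open whether the cyano step would be repeated on an aryl carrying chlorine, as in compound 1 and compound 3.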